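The source may hold more compounds than are shown below. What is called first, only, known or untested is meant among the compounds shown, and "the series" means these compounds.

Measured so far in a functional assay on the whole organism for inhibition, with Mus musculus as the target (on this read-out higher numbers stand for an effect only at larger amounts of compound and lower numbers for an effect already at smaller amounts), are three compounds
Compound 1 `CCCCNC(=O)Nc1cccc2c1CN(C)CC2c1ccccc1` gives about 40 mg/kg
Compound 2 `CCOC(=O)Nc1cccc2c1CN(C)CC2c1ccccc1` gives 3.2 mg/kg
Compound 3 `CCOC(=O)Nc1cccc2c1CN(C)CC2c1ccc(F)cc1` gives 3.5 mg/kg

Compound 2 sits at the low end of these numbers, level with compound 3 and far from compound 1 on this scale. Compound 4 `CCCCNCC(=O)Nc1cccc2c1CN(C)CC2c1ccccc1` changes compound 2 with (butylamino)methyl in place of ethoxy on a carbonyl carbon and is still to be measured. Compound 4 gives up the ethoxy and gains a butylamino-bearing group, so the reverse of a 13-fold lower number from compound 1 to compound 2 (1.10 log units; beyond the scatter) is the closest guide. Fluoro in place of hydrogen on an aromatic carbon gave a 1.1-fold higher number from compound 2 to compound 3 (0.04 log units; within the scatter) and does not touch this carbonyl carbon. For the measured compounds named here, no measured compound carries the (butylamino)methyl group, so the guide is only partial. A clear rise is therefore expected, estimated as a 4.7-fold higher number from compound 2 to compound 4 (0.67 log units; beyond the scatter) in this assay and likely smaller than the guiding step. For compound 4 the expected value is 15 mg/kg with an estimated range from 5 mg/kg to 50 mg/kg on this read-out.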

Compound 4, dose for half-maximal effect: 32 mg/kg
Estimate against measurement, compound 4: 2.1-fold (0.33 log units) below, and the stated range covers the measured number.
By their numbers in this assay, from the lowest: compounds 2 and 3 (each within the scatter of the next); then compounds 4 and 1 (each within the scatter of the next).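

Putting (butylamino)methyl in place of ethoxy on this carbonyl carbon gives a 10-fold higher number from compound 2 to compound 4 (1.00 log units; beyond the scatter), so a second group, besides butylamino, fails to keep the effect at the small doses seen with ethoxy. Set against butylamino, the same group gives a 1.3-fold lower number from compound 1 to compound 4 (0.10 log units; within the scatter), so these two groups cannot be told apart in this read-out. Nothing available explains the loss from ethoxy.

As far as these compounds go, it remains open whether methoxy or butoxy on this carbonyl carbon would keep the effect at small doses. From the compounds shown here alone, a chain ending in a dimethylamino group also remains untested here as a replacement for the butylamino end.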